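This account rests on a few compounds, and the source may have more. Where it says the series, first, only, none or still open, it means among the compounds named here.

Compound 1 `O=C(CN(Cc1ccc(Cl)cc1)C1CCCCC1)Nc1cc(F)cc(F)c1`: in an assay on HEK293 cells for inhibition of sodium- and chloride-dependent glycine transporter 1 (Homo sapiens), read by scintillation proximity assay (a lower number here means a stronger inhibitor, a higher number a weaker inhibitor), compound 1 gives > 25100 nM, which is a limit of the assay and not a number.
Compound 2 `O=C(CN(C(=O)c1cccnc1)C1CCCCC1)Nc1cc(F)cc(F)c1`: in this assay compound 2 gives > 25100 nM, likewise a limit.

Compound 2 therefore stands at the edge of what this assay can report, and compound 1 stands there with it, since both values sit at the limit of > 25100 nM in this assay, at which 2 of the 2 values shown sit. Going by the values given here, the only measured step, a step that the two limits leave unreadable from compound 1 to compound 2, cannot be read because both of its ends rest on (the limit of > 25100 nM in this assay, at which 2 of the 2 values shown sit). Compound 3 `O=C(CN(C(=O)c1cccc(Cl)c1)C1CCCCC1)Nc1cc(F)cc(F)c1` differs from compound 2 in one place: 3-chlorophenyl in place of pyridin-3-yl on a carbonyl carbon. Among the compounds with values here, no measured step touches this change, so there is no precedent that would point to a move in either direction; the only information is that compound 2 already shows no measurable inhibition. On that basis the step from compound 2 to compound 3 is expected to be a step that the limit leaves unreadable from compound 2 to compound 3, which means no readable shift beyond the scatter. Compound 3 is accordingly estimated at 30000 nM in this assay, within a range from 5000 nM to 100000 nM, with a high chance that only a limit is reported again.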

Compound 3, half-maximal inhibitory concentration: 1580 nM
Compound 3: middle estimate off by 19-fold (1.28 log units), on the high side, and the stated range ends above it.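

Going by these compounds alone, on the carbonyl carbon, this is the first change to give a readable result: in this assay, 3-chlorophenyl in place of pyridin-3-yl gives an at least 15-fold lower number from compound 2 to compound 3 (1.20 log units; beyond the scatter). The change on the amine nitrogen is also readable, with (3-chlorophenyl)carbonyl in place of 4-chlorobenzyl giving an at least 15-fold lower number from compound 1 to compound 3 (1.20 log units; beyond the scatter), so a chlorine-bearing ring on that nitrogen is not enough by itself, since compound 1 also carries one and still reaches no measurable value. Both steps give only the smallest possible size, and the step between the two earlier compounds cannot be read at all, because the values of compound 1 and compound 2 are limits rather than numbers: the limit of > 25100 nM in this assay, at which 2 of the 3 values shown sit.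

The swap from pyridin-3-yl to 3-chlorophenyl removes the ring nitrogen and adds a chlorine at once, so these compounds cannot show which of the two changes accounts for the gain. A plain phenyl group on the same carbonyl carbon would separate those two changes, while a 3-fluorophenyl or 3-methoxyphenyl group would show whether chlorine itself is needed there.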